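A few compounds are considered here, and "the series" means these few. Any claim that something is new, unique, unknown or untested is made for them only; others in the source may bear on it.

Compounds measured so far:

Compound 1, `CC(C)C[C@H](N)c1cc(Cl)ccc1N1CCN(C(=O)C2NCCC2c2ccc(Cl)cc2)CC1`, in an assay on HEK293 cells for displacement of a labelled ligand from Melanocortin receptor 4 (Homo sapiens) (on this read-out higher numbers stand for weaker inhibition and lower numbers for stronger inhibition), compound 1 gives 96 nM.
Compound 2, `CCOC(=O)N1CC[C@H](c2ccc(Cl)cc2)[C@H]1C(=O)N1CCN(c2ccc(C)cc2[C@@H](N)C(C)C)CC1`, in this assay compound 2 gives 42 nM.
Compound 3, `CC(=O)N1CC[C@H](c2ccc(C(F)(F)F)cc2)[C@@H]1C(=O)N1CCN(c2ccc(C)cc2[C@@H](N)C(C)C)CC1`, in this assay compound 3 gives 54 nM.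

Of the three numbers, that of compound 2 is the lowest. Its nearest neighbour is compound 3, whose number is higher by an amount that stays within the scatter, so no order can be read between compound 2 and compound 3. Compound 1 is the furthest from compound 2, and its higher number does lie beyond the scatter.

The step now followed leads from compound 2 to compound 4, `CCC(=O)N1CC[C@H](c2ccc(Cl)cc2)[C@H]1C(=O)N1CCN(c2ccc(C)cc2[C@@H](N)C(C)C)CC1`, which has not yet been measured in this assay. The change is ethyl in place of ethoxy on a carbonyl carbon; cut one bond further out it reads ethoxycarbonyl to propanoyl. The core and everything else in the molecule stay as in compound 2.

Among the compounds with values here, no measured pair in this set shows what such an exchange on that carbonyl carbon does. With nothing to point in either direction, the account expects the step from compound 2 to compound 4 in this assay to be a 1.1-fold higher number from compound 2 to compound 4 (0.03 log units; within the scatter), that is, no change beyond the scatter. Compound 4 is therefore estimated at 45 nM, with a range from 20 nM to 110 nM.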

Compound 4, inhibition constant: 62 nM
Estimate against measurement, compound 4: 1.4-fold (0.14 log units) below, and the stated range covers the measured number.
By their numbers in this assay, from the lowest: compounds 2, 3, 4 and 1 (each within the scatter of the next, the first and the last beyond it).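

In this assay, within the data shown here, putting ethyl in place of ethoxy on the carbonyl carbon gives a 1.5-fold higher number from compound 2 to compound 4 (0.17 log units; within the scatter), the first reading of any single change at this place, and the step stays within the scatter. With everything else in the molecule held as in compound 2, the oxygen of the ethoxy group, with the hydrogen-bond acceptor counted for it and one heavy atom, can therefore go without a change that can be told from repeat measurement, so ethoxycarbonyl and propanoyl cannot be ordered on this read-out. No supporting data bear on this result.

Among these compounds, this one step shows only that these two groups cannot be told apart on the shared core, and it does not show how much variation the position will bear. From the compounds shown here alone, whether a longer chain such as butanoyl, or an amine such as dimethylamino on the same carbonyl carbon, would also stay within the scatter in this assay remains open, as does whether the same exchange would read alike with different groups elsewhere in the molecule.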